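The compounds below may be only part of what the source reports. "The series", "measured", "known", "first", "only" and "open" are said of these compounds alone.

Measured compounds:
compound 1 `CN1[C@@H]2c3[nH]c4ccccc4c3C[C@H]1[C@H](C#N)N1[C@@H](CNC(=O)c3ccc4ccccc4n3)c3[nH]c4ccccc4c3C[C@@H]21` — 240 nM
compound 2 `CN1[C@@H]2c3[nH]c4ccccc4c3C[C@H]1[C@H](C#N)N1[C@@H](CNC(=O)c3cc4ccccc4s3)c3[nH]c4ccccc4c3C[C@@H]21` — 500 nM

For the measured compounds named here, in a functional assay on HCT-116 cells (Homo sapiens) for cytotoxicity, read by MTT assay, with a stated time of 72 h (a higher number here means a weaker inhibitor, a lower number a stronger inhibitor), compound 2 holds the higher of the two numbers, the single measured step being a 2.1-fold higher number from compound 1 to compound 2 (0.32 log units; beyond the scatter). Compound 3 `CN1[C@@H]2c3[nH]c4ccccc4c3C[C@H]1[C@H](C#N)N1[C@@H](CNC(=O)c3cc4ccccc4o3)c3[nH]c4ccccc4c3C[C@@H]21` differs from compound 2 by 1-benzofuran-2-yl in place of 1-benzothiophen-2-yl on a carbonyl carbon. Going by the values given here, no measured step replaces sulfur by oxygen in this ring; the one known step alters a different group, so it gives no direction for this change. The expected step is a 1.2-fold lower number from compound 2 to compound 3 (0.08 log units; within the scatter), within the scatter. Compound 3 is therefore estimated at 420 nM, with a range from 160 nM to 1100 nM.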

Compound 3, half-maximal inhibitory concentration: 330 nM
The estimate for compound 3 lay 1.3-fold (0.10 log units) above the measured number, within the range that was stated.
By their numbers in this assay, from the lowest: compounds 1, 3 and 2 (each within the scatter of the next, the first and the last beyond it).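

In this assay, 1-benzofuran-2-yl in place of 1-benzothiophen-2-yl on a carbonyl carbon gives a 1.5-fold lower number from compound 2 to compound 3 (0.18 log units; within the scatter), and 1-benzofuran-2-yl in place of quinolin-2-yl gives a 1.4-fold higher number from compound 1 to compound 3 (0.14 log units; within the scatter). Compound 3 therefore cannot be separated from compound 1 or compound 2, even though those two lie beyond the scatter of each other. Exchanging sulfur for oxygen in this ring thus leaves no readable difference at this place. From the compounds shown here alone, whether an amine or a carboxylic acid on the 1-benzofuran-2-yl group, or a plain alkyl chain in its place on the carbonyl carbon, would keep such numbers remains open. Nothing available accounts for these numbers.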